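This account rests on a few compounds, and the source may have more. Where it says the series, first, only, none or still open, it means among the compounds named here.

Compounds measured so far in an assay on V79MZh cells for inhibition of cytochrome P450 11B1, mitochondrial (Homo sapiens), with a stated time of 6 h; a lower number here means a stronger inhibitor, a higher number a weaker inhibitor:

- compound 1, `O=c1cc(Cc2ccncc2)oc2ccccc12`: 223 nM
- compound 2, `COc1ccc2c(=O)cc(Cc3ccncc3)oc2c1`: 3600 nM

Among the compounds with values here, compound 2 stands at the highest of the two numbers in this assay, with compound 1 as its only neighbour; the step of a 16-fold higher number from compound 1 to compound 2 (1.21 log units; beyond the scatter) is the only measured step, and it is large, beyond the scatter.

Compound 3, `O=c1cc(Cc2ccncc2)oc2cc(F)ccc12`, is not yet measured. It differs from compound 2 in one place: fluoro in place of methoxy on an aromatic carbon.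

Within the data shown here, the single measured step that bears on this change is a 16-fold higher number from compound 1 to compound 2 (1.21 log units; beyond the scatter), which shows what adding the methoxy at this carbon does. Taking it away again should give back part or all of that step; what the fluoro adds in its place is not known from any measured pair in this series, so compound 1 and compound 2 bracket the likely outcome. The expected direction for compound 3 in this assay is therefore a lower number than compound 2, with a step of about a 6.0-fold lower number from compound 2 to compound 3 (0.78 log units; beyond the scatter) expected. On that basis compound 3 is estimated at 600 nM in this assay, with a range from 200 nM to 2000 nM.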

Compound 3, half-maximal inhibitory concentration: 82.7 nM
Beside the measured number, compound 3's estimate is 7.3-fold (0.86 log units) above it; measured number outside the range, below it.
By their numbers in this assay, from the lowest: compound 3; then compound 1; then compound 2.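

In this assay fluoro in place of methoxy on this aromatic carbon gives a 44-fold lower number from compound 2 to compound 3 (1.64 log units; beyond the scatter), and fluoro in place of hydrogen gives a 2.7-fold lower number from compound 1 to compound 3 (0.43 log units; beyond the scatter), so removing the methoxy is not the whole story: the fluoro adds a modest gain of its own over the unsubstituted core of compound 1. The carbon is therefore not one where any substituent raises the number, since methoxy and fluoro move it in opposite directions from compound 1, each by a step beyond the scatter, and compound 3 now has the lowest number of the three. Nothing measured on these compounds explains why the two groups part ways here.

From the compounds shown here alone, with only hydrogen, methoxy and fluoro at this carbon, it remains open whether a chloro, a methyl, a hydroxyl or a trifluoromethyl group would follow compound 3 or compound 2. Going by these compounds, whether fluoro gives a similar gain on the other aromatic carbons of the shared core also remains open, as does whether it would do so with the side chain changed.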